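A few compounds are considered here, and "the series" means these few. Any claim that something is new, unique, unknown or untested is made for them only; others in the source may bear on it.

Measured so far:
Compound 1 `Cc1cc(NCc2ccccn2)n2ncc(-c3cccc(F)c3)c2n1` gives 5000 nM in a physicochemical assay for solubility, read by HPLC, using the shake flask method, measured as kinetic solubility, with a stated time of 2 h, at pH 7.4; on this read-out lower numbers stand for lower solubility and higher numbers for higher solubility.
Compound 2 `Cc1cc(NCc2ccccn2)n2ncc(C3=CCC(F)(F)CC3)c2n1` gives 5000 nM in this assay.

Compound 2 stands level with compound 1: the step of no change at the digits printed from compound 1 to compound 2 (within the scatter) shows that swapping one ring for the other left the read-out where it was. The next step goes from compound 2 to compound 3 `Cc1cc(NCc2ccccn2)n2ncc(-c3ccc(O)cc3)c2n1`, with 4-hydroxyphenyl in place of 4,4-difluorocyclohex-1-en-1-yl on an aromatic carbon. Within the data shown here, the one measured step, no change at the digits printed from compound 1 to compound 2 (within the scatter), is the only guide, and it moved nothing beyond the scatter; it traded a fluorinated aromatic ring for a fluorinated non-aromatic ring, whereas the present change brings in a 4-hydroxyphenyl group, for which no measured step exists. A step of modest size at most is therefore expected, possibly toward higher solubility, though a result within the scatter is just as plausible. For compound 3 the expected step is a 1.2-fold higher number from compound 2 to compound 3 (0.08 log units; within the scatter). The estimated value for compound 3 is 6000 nM, with a range from 3000 nM to 15000 nM.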

Compound 3, solubility: 10900 nM
Beside the measured number, compound 3's estimate is 1.8-fold (0.26 log units) below it, within the range that was stated.
By their numbers in this assay, from the lowest: compounds 1 and 2 (each within the scatter of the next); then compound 3.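

Putting 4-hydroxyphenyl on this aromatic carbon gives a 2.2-fold higher number from compound 2 to compound 3 (0.34 log units; beyond the scatter) when it replaces 4,4-difluorocyclohex-1-en-1-yl, and a 2.2-fold higher number from compound 1 to compound 3 (0.34 log units; beyond the scatter) when it replaces 3-fluorophenyl. The position can therefore move the read-out in this assay beyond the scatter, although the swap between those two fluorinated groups left it level, and the two modest steps are the same size. Nothing measured here explains the rise, and 4-hydroxyphenyl differs from 4,4-difluorocyclohex-1-en-1-yl in several ways at once, including its aromatic ring, its oxygen and its hydrogen-bond donor.

As far as these compounds go, what remains open is whether the hydroxyl group itself matters, which a plain phenyl or a methoxy-bearing phenyl ring at this carbon could help to show. From the compounds shown here alone, it is also open whether an amine or a carboxylic acid on that ring would shift the number further.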